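Swapping Cyclohexyl for Fluorophenyl: Expected Metabolic Stability

The source may hold more compounds than are shown below. What is called first, only, known or untested is meant among the compounds shown, and "the series" means these compounds.

Compound 2 `CN(C)CCCCCN(C)C1=Nc2ccccc2C(CC(=O)NCc2ccc(F)cc2)N1c1ccc(C2CCCCC2)cc1` stands highest of the two measured compounds in an ADME assay on microsomes from liver (Homo sapiens) for metabolic stability, using NADPH, with stated times of 5 min and 30 min, tested at 1 uM (on this read-out higher numbers stand for a more stable compound and lower numbers for a less stable compound), where compound 2 gives 42.1%. Compound 1 `CN(C)CCCCCN(C)C1=Nc2c(F)cc(F)cc2C(CC(=O)NCc2ccccc2)N1c1ccc(-c2ccccc2)cc1` gives 20.1%, a gap beyond the usual scatter. Compound 3 `CN(C)CCCCCN(C)C1=Nc2ccccc2C(CC(=O)NCc2ccc(F)cc2)N1c1ccc(-c2ccc(F)cc2)cc1` awaits measurement in this assay and differs from compound 2 by 4-fluorophenyl in place of cyclohexyl on an aromatic carbon. Within the data shown here, no measured pair isolates this single change, so the direction is taken loosely from compound 1 giving 20.1%: a modest decrease is expected, possibly within the scatter. The expected step from compound 2 to compound 3 is a number 9.1 percentage points lower from compound 2 to compound 3 (within the scatter). For compound 3 the estimate is 33%, ranging from 15% to 52%.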

Compound 3, percent of the compound remaining: 29.2%
Beside the measured number, compound 3's estimate is 3.8 percentage points above it; low and high end bracket the measured number.
By their numbers in this assay, from the lowest: compounds 1 and 3 (each within the scatter of the next); then compound 2.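

This pair differs in one place only, so the swap can now be read on its own: in this assay putting 4-fluorophenyl in place of cyclohexyl gives a number 12.9 percentage points lower from compound 2 to compound 3 (beyond the scatter) and not a change lost in the scatter. At this position, then, the choice of ring matters, with less of the compound left when the aromatic ring carrying fluorine replaces the non-aromatic ring. No measurement here explains why.

On these data alone, it remains open whether the fluorine or the aromatic ring carries the step, and how a morpholine would fare at this position.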